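Swapping the aryl group on the sulfone of compound 1

The source may report more compounds than this note shows. Statements on the series, on what has been measured and on what is new or still open speak of the compounds shown alone.

Compound 1 `CC(O)(C(=O)Nc1ccc(S(=O)(=O)c2ccccc2F)cc1)C(F)(F)F` is the stronger of the two measured compounds. In a functional assay (Cavia porcellus) with sulfonylurea receptors; K-ATP channels (Homo sapiens) as the target (a higher number here means a weaker inhibitor, a lower number a stronger inhibitor), compound 1 gives 1300 nM, while compound 2 `CC(O)(C(=O)Nc1ccc(C#N)c(Sc2ccccc2)c1)C(F)(F)F` gives 8300 nM, a gap that lies beyond the usual scatter. Compound 3 `COc1ccc(S(=O)(=O)c2ccc(NC(=O)C(C)(O)C(F)(F)F)cc2)cc1` has not been measured. It differs from compound 1 in one place: 4-methoxyphenyl in place of 2-fluorophenyl on a sulfonyl sulfur. Among the measured compounds shown here, no measured pair shows what such a swap does, so only a small step in either direction is expected, and it may stay within the scatter. The expected step from compound 1 to compound 3 is a 1.2-fold higher number from compound 1 to compound 3 (0.09 log units; within the scatter). Compound 3 is estimated at 1600 nM, between 500 nM and 5000 nM.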

Compound 3, half-maximal inhibitory concentration: > 30000 nM
Compound 3 ended at the assay's limit; the forecaster's own chance of this, stated with the estimate: 5%; at least 18-fold (1.27 log units) between middle value and limit.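

The aryl group on the sulfonyl sulfur matters a great deal: in this assay, 4-methoxyphenyl in place of 2-fluorophenyl gives an at least 23-fold higher number from compound 1 to compound 3 (1.36 log units; beyond the scatter). Compound 3 stands at > 30000 nM, which is a limit of the assay and not a number. This single swap removes one group and brings in another, so it cannot separate the loss of 2-fluorophenyl from the arrival of 4-methoxyphenyl. From the compounds shown here alone, whether unsubstituted phenyl or 4-aminophenyl on the same sulfonyl sulfur would stay close to compound 1 remains open.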